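Lipophilicity notes: pyridyl-to-imidazolyl swap on the shared core

The compounds below may be only part of what the source reports. "The series", "measured", "known", "first", "only" and "open" are said of these compounds alone.

Two compounds of the series have numbers in a physicochemical assay for lipophilicity, using the shake flask method, in phosphate buffer, measured as octanol-water partition, with a stated time of 30 min, at pH 7.4; on this read-out higher numbers stand for higher lipophilicity and lower numbers for lower lipophilicity. Compound 1 `Cc1nc(CO)ccc1-c1cnc(NCc2c(F)ccc3c2CCO3)c2cn[nH]c(=O)c12` gives 2.4 in this assay and stands highest of the two. Compound 2 `CN(c1ccn(C)n1)c1cnc(NCc2c(F)ccc3c2CCO3)n2cnnc12`, built on a different core, gives 1.8 in this assay, a lower value that sits beyond the usual scatter from compound 1. Going by the values given here, no pair of measured compounds differs in a single place, so no measured step is available as a guide for the change considered next.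

Compound 3 `CNC(=O)c1ncc(-c2cnc(NCc3c(F)ccc4c3CCO4)c3cn[nH]c(=O)c23)n1C` has not yet been measured in this assay. It differs from compound 1 in one place: 1-methyl-2-(methylcarbamoyl)-1H-imidazol-5-yl in place of 6-(hydroxymethyl)-2-methylpyridin-3-yl on an aromatic carbon. The hydroxymethyl-bearing six-membered ring leaves and a five-membered ring carrying a methylcarbamoyl group enters, with one more hetero atom and one more hydrogen-bond acceptor counted.

For compound 3 the expected step of a number 0.50 log units lower from compound 1 to compound 3 (beyond the scatter) is downward, modest in size and probably somewhat beyond the scatter. Compound 3 is estimated at 1.9 in this assay, within a range from 1.3 to 2.5.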

Compound 3, distribution coefficient: 2.5
Beside the measured number, compound 3's estimate is 0.60 log units below it; measured number inside the range.
By their numbers in this assay, from the lowest: compound 2; then compounds 1 and 3 (each within the scatter of the next).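

In this assay, going by these compounds alone, the first single-place step reads a number 0.10 log units higher from compound 1 to compound 3 (within the scatter) and comes from placing 1-methyl-2-(methylcarbamoyl)-1H-imidazol-5-yl where 6-(hydroxymethyl)-2-methylpyridin-3-yl stood on the aromatic carbon of the shared core. At this position, therefore, a five-membered aromatic ring with 2 hetero atoms and 3 hydrogen-bond acceptors can replace a six-membered aromatic ring with 1 hetero atom and 2 hydrogen-bond acceptors without a step beyond the scatter on this read-out. No measurement at hand bears on why the two groups give values within the scatter of each other.

Within the data shown here, the exchange alters the ring, its methyl placement and the hydrogen-bond donor group all at once, so the share of each part stays open, and the single step cannot show whether separate contributions offset one another or each is small. Also open, as far as these compounds go, is how this read-out responds at the same carbon to groups of another kind, such as a carboxylic acid or a dimethylamino group in place of the methylcarbamoyl on the imidazole, or an unsubstituted phenyl ring in place of the whole substituent.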